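Ring swap on the aryl ether series: imidazole for isothiazole

This account rests on a few compounds, and the source may have more. Where it says the series, first, only, none or still open, it means among the compounds named here.

For the measured compounds named here, compound 3 `c1ccc(-c2ccns2)c(OCC2=NCCN2)c1` gives 12.6 nM in a functional assay for activation of Alpha-1B adrenergic receptor (Homo sapiens), read by calcium flux (on this read-out lower numbers stand for an effect already at smaller amounts and higher numbers for an effect only at larger amounts of compound), which is the highest of the two numbers so far; the nearest is compound 2 `c1csc(-c2ccccc2OCC2=NCCN2)c1` with 3.98 nM, and the step of a 3.2-fold higher number from compound 2 to compound 3 (0.50 log units; beyond the scatter) is a modest one. Compound 1 `c1ccc(-c2ccncn2)c(OCC2=NCCN2)c1` shows only a limit, < 100000 nM, so a step that the limit leaves unreadable from compound 1 to compound 2 and a step that the limit leaves unreadable from compound 1 to compound 3 cannot be sized. Compound 4 `c1ccc(-c2ncc[nH]2)c(OCC2=NCCN2)c1` differs from compound 3 by 1H-imidazol-2-yl in place of 1,2-thiazol-5-yl on an aromatic carbon. Going by the values given here, no measured pair shows this particular exchange; the only readable step among the measured compounds is the change of the five-membered ring from thiophen-2-yl to 1,2-thiazol-5-yl, which shifted the number by a modest amount. A change of similar scale in either direction is therefore expected, with no firm pull one way, and a somewhat higher number is taken as the working guess, meaning an expected step of a 3.2-fold higher number from compound 3 to compound 4 (0.50 log units; beyond the scatter). Compound 4 is estimated at 40 nM in this assay, within a range from 6 nM to 300 nM.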

Compound 4, half-maximal effective concentration: < 100000 nM
Compound 4: a limit, no number; the forecaster's own chance of this, stated with the estimate: 5%; the middle value is on the limit's open side.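

Compound 4 gives only a limit in this assay, and no step to it from compound 1, compound 2 or compound 3 can be read: the limit of < 100000 nM in this assay, at which 2 of the 4 values shown sit.

The compounds shown leave open how far compound 4 and compound 1 actually stand from compound 2 and compound 3, and how those two compounds compare with each other.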